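Moving the halogen around the benzyl ring of a dithiocarbamate

The source may hold more compounds than are shown below. What is called first, only, known or untested is meant among the compounds shown, and "the series" means these compounds.

Measured compounds:
- compound 1, `Fc1ccccc1Cn1cc(CSC(=S)N2CCNCC2)nn1`: > 128000 nM (a limit)
- compound 2, `O=C(OCc1ccccc1)N1CCN(C(=S)SCc2cn(Cc3ccc(F)cc3)nn2)CC1`: 32000 nM
- compound 3, `S=C(SCc1cn(Cc2ccc(Cl)cc2)nn1)N1CCNCC1`: > 128000 nM (a limit)

Among the compounds with values here, in a functional assay on ECa-109 cells (Homo sapiens) for inhibition, read by MTT assay, with a stated time of 72 h (on this read-out lower numbers stand for stronger inhibition and higher numbers for weaker inhibition), compound 2 gives 32000 nM, the only actual number among the three values shown. Compound 1 gives only a limit of the assay, > 128000 nM. Compound 3 likewise gives only a limit, > 128000 nM. Because both sit at the limit of > 128000 nM in this assay, at which 2 of the 3 values shown sit, the step that the two limits leave unreadable from compound 1 to compound 3 cannot be read, so nothing is known about how swapping one halogenated phenyl for another on the saturated chain carbon bound to an aromatic nitrogen affects the read-out.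

Compound 4, `O=C(OCc1ccccc1)N1CCN(C(=S)SCc2cn(Cc3ccccc3Cl)nn2)CC1`, is not yet measured. It differs from compound 2 in one place: 2-chlorophenyl in place of 4-fluorophenyl on a saturated chain carbon bound to an aromatic nitrogen. Within the data shown here, no measured step bears on this change in a readable way; the one related step is hidden behind the limits. The expectation therefore rests on compound 2 alone, and no step beyond the scatter is expected in either direction. Compound 4 is estimated to give 40000 nM in this assay, in the range 10000 nM to 160000 nM, which means an expected step of a 1.3-fold higher number from compound 2 to compound 4 (0.10 log units; within the scatter).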

Compound 4, half-maximal inhibitory concentration: 56800 nM
Beside the measured number, compound 4's estimate is 1.4-fold (0.15 log units) below it; the measured number falls inside the stated range.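

In this assay, within the data shown here, putting 2-chlorophenyl in place of 4-fluorophenyl on a saturated chain carbon bound to an aromatic nitrogen gives a 1.8-fold higher number from compound 2 to compound 4 (0.25 log units; within the scatter), which makes this the first readable change of halogenated phenyl at this place. The earlier swap, between compound 1 and compound 3, cannot be read, because each of those two compounds gives only a limit: the limit of > 128000 nM in this assay, at which 2 of the 4 values shown sit. The new pair shows that these two halogenated phenyl groups cannot be told apart in this read-out, although that finding holds for this one pair and does not establish a general rule for the position.

This single change alters both the halogen and its place on the ring, so the compounds shown cannot separate the contribution of fluorine versus chlorine from that of 4 versus 2 on the ring. They also leave open what would happen with a phenyl carrying an amine or a carboxylic acid instead of a halogen, or with a longer chain joining the phenyl to the aromatic nitrogen.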